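This account rests on a few compounds, and the source may have more. Where it says the series, first, only, none or still open, it means among the compounds named here.

Compound 1, `CCc1ccc(-c2nc3c(c(C)nn3-c3ccccc3)c(-c3ccccc3I)c2C#N)cc1`: 8500 nM
Compound 2, `CCc1ccc(-c2nc3c(c(C)nn3-c3ccccc3)c(-c3ccccc3F)c2C#N)cc1`: 1700 nM
Compound 3, `CCc1ccc(-c2nc3c(c(C)nn3-c3ccccc3)c(-c3ccc(O)cc3)c2C#N)cc1`: 5700 nM

In a physicochemical assay for solubility, read by spectrophotometry, in phosphate buffer, with a stated time of 18 h, at pH 7.4 (on this read-out higher numbers stand for higher solubility and lower numbers for lower solubility), compound 2 stands lowest of the three numbers; the gap to compound 3 and the larger gap to compound 1 both lie beyond the scatter. Compound 4, `C#Cc1ccccc1-c1c(C#N)c(-c2ccc(CC)cc2)nc2c1c(C)nn2-c1ccccc1`, differs from compound 2 in one place: ethynyl in place of fluoro on an aromatic carbon. The step that bears most on this change is a 5.0-fold lower number from compound 1 to compound 2 (0.70 log units; beyond the scatter), since iodo and ethynyl both occupy the same position in the ring and each is larger than fluoro. The step of a 3.4-fold higher number from compound 2 to compound 3 (0.53 log units; beyond the scatter) shows that leaving fluoro at this position has so far gone with a higher number in either direction. Compound 4 is therefore expected to give about 4500 nM, with a range of 1800 nM to 11000 nM. The expected step of a 2.6-fold higher number from compound 2 to compound 4 (0.42 log units; beyond the scatter) is thus a modest rise beyond the scatter.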

Compound 4, solubility: 46000 nM
For compound 4 the middle estimate is 10-fold (1.01 log units) below the measured one; measured number above the stated range.
By their numbers in this assay, from the lowest: compound 2; then compounds 3 and 1 (each within the scatter of the next); then compound 4.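

In this assay the ethynyl group on this aromatic carbon gives the highest number of the four, with a 27-fold higher number from compound 2 to compound 4 (1.43 log units; beyond the scatter) as the largest step shown, and with an 8.1-fold higher number from compound 3 to compound 4 (0.91 log units; beyond the scatter) and a 5.4-fold higher number from compound 1 to compound 4 (0.73 log units; beyond the scatter) also beyond the scatter. The earlier rise from fluoro to iodo therefore did not mark the top of the range at this position. Nothing shown accounts for the size of this rise.

The compounds shown leave open how an amine or a longer alkyne chain would read at this place. They also leave open whether ethynyl elsewhere on the ring would give a similar rise.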